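A Second Hydroxy Group on Compound 3

The compounds below may be only part of what the source reports. "The series", "measured", "known", "first", "only" and "open" are said of these compounds alone.

In a functional assay on PC-3 cells (Homo sapiens) for antiproliferative activity, read by MTT assay, with a stated time of 72 h (a higher number here means a weaker inhibitor, a lower number a stronger inhibitor), compound 1 (`O=C(N/N=C/c1ccc([N+](=O)[O-])cc1)Nc1ccc(Oc2ccnc3[nH]ccc23)c(F)c1`) gives 150 nM and compound 2 (`O=C(N/N=C/c1ccc(Cl)c(Cl)c1)Nc1ccc(Oc2ccnc3[nH]ccc23)c(F)c1`) gives 14100 nM while compound 3 (`O=C(N/N=C/c1ccc(O)cc1)Nc1ccc(Oc2ccnc3[nH]ccc23)c(F)c1`) gives 2780 nM as the middle of the three numbers. Compound 4 (`O=C(N/N=C/c1ccc(O)cc1O)Nc1ccc(Oc2ccnc3[nH]ccc23)c(F)c1`) carries hydroxy in place of hydrogen on an aromatic carbon, ortho to a large group and meta to a hydroxy group (hydroxy in place of hydrogen on an aromatic carbon). Among the compounds with values here, no measured step adds a second hydroxy. The nearest steps (a 19-fold higher number from compound 1 to compound 3 (1.27 log units; beyond the scatter) and a 5.1-fold lower number from compound 2 to compound 3 (0.71 log units; beyond the scatter)) show that exchanges on this ring can be large or modest, yet neither gives a direction here, so at most a modest step, in no firm direction, is expected in this assay for this change. The estimate means a 1.4-fold lower number from compound 3 to compound 4 (0.14 log units; within the scatter) as the expected step. Compound 4 is estimated at 2000 nM with 500 nM to 8000 nM as the expected range.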

Compound 4, half-maximal inhibitory concentration: 13000 nM
Estimate against measurement, compound 4: 6.5-fold (0.81 log units) below; the whole stated range lies below it.
By their numbers in this assay, from the lowest: compound 1; then compound 3; then compounds 4 and 2 (each within the scatter of the next).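

With a 4.7-fold higher number from compound 3 to compound 4 (0.67 log units; beyond the scatter) in this assay as the only measured step at this position, hydroxy in place of hydrogen on this aromatic carbon, ortho to a large group, is shown to raise the number beyond the scatter. With a 1.1-fold lower number from compound 2 to compound 4 (0.04 log units; within the scatter) the 2,4-dihydroxyphenyl and 3,4-dichlorophenyl groups cannot be told apart, while an 87-fold higher number from compound 1 to compound 4 (1.94 log units; beyond the scatter) leaves 4-nitrophenyl well separated from 2,4-dihydroxyphenyl. Nothing available speaks to the cause of this step.

From the compounds shown here alone, whether methoxy or an amine on this same carbon would move the number the same way remains open. So does whether hydroxy there gives such a step without the other hydroxy group on the ring.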